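A few compounds are considered here, and "the series" means these few. Any claim that something is new, unique, unknown or untested is made for them only; others in the source may bear on it.

Of the compounds shown here, three that share one core have been tested in an ADME assay on L929 cells (Mus musculus) for cytotoxicity, read by resazurin assay, with a stated time of 72 h; a higher number here means a weaker inhibitor, a lower number a stronger inhibitor. Compound 1 `COCOc1cccc(C(=O)/C=C/c2ccc3c(c2)B(O)OC3)c1` gives > 10 ug/mL there, which is a limit of the assay rather than a number. Compound 2 `O=C(/C=C/c1ccc2c(c1)B(O)OC2)c1ccccn1` likewise gives > 10 ug/mL in this assay, again a limit. Compound 3 `O=C(/C=C/c1ccc2c(c1)B(O)OC2)c1ccc(C(F)(F)F)cc1` gives > 10 ug/mL in this assay, also a limit. Compound 3 therefore stands exactly where the other two measured compounds stand, at the limit of > 10 ug/mL in this assay, at which 3 of the 3 values shown sit, so none of the three can be placed above or below another on these numbers.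

The next compound, compound 4 `O=C(/C=C/c1ccc2c(c1)B(O)OC2)c1ccc(-c2ccccc2)cc1`, differs from compound 3 in one place: phenyl in place of trifluoromethyl on an aromatic carbon. Among the compounds with values here, no step between two measured compounds is known, so nothing shows how this assay answers a change on the shared core, and the three limits give no direction to follow. The expected step is a step that the limit leaves unreadable from compound 3 to compound 4, nothing beyond the scatter. Compound 4 is estimated at 15 ug/mL in this assay, within a range from 5 ug/mL to 40 ug/mL, and it is expected that this assay will again report only a limit.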

Compound 4, half-maximal inhibitory concentration: > 10 ug/mL
Compound 4: only a limit was reported (the forecaster's own chance of this, stated with the estimate: 75%); the middle value does not contradict the limit.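

No step from compound 3 to compound 4 can be read, since both results in this assay are limits and not numbers: the limit of > 10 ug/mL in this assay, at which 4 of the 4 values shown sit.

The compounds shown leave open where any of them truly lies beyond that limit, and whether any change on the shared core would give a measurable value in this assay.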